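Swapping the Aryl Group on the Sulfonyl Sulfur

This account rests on a few compounds, and the source may have more. Where it says the series, first, only, none or still open, it means among the compounds named here.

Of the compounds shown here, two sharing one core have been measured in a functional assay (Cavia porcellus) with sulfonylurea receptors; K-ATP channels (Homo sapiens) as the target; a lower number here means a stronger inhibitor, a higher number a weaker inhibitor. Compound 1 (`COc1ccc(S(=O)(=O)c2ccc(NC(=O)C(C)(O)C(F)(F)F)cc2)cc1`) carries a 4-methoxyphenyl on the sulfonyl sulfur; in this assay compound 1 reaches only the limit of > 30000 nM, which is not a number but the edge of what the assay can report. Within the data shown here, compound 2 (`CC(O)(C(=O)Nc1ccc(S(=O)(=O)c2ccccc2Cl)cc1)C(F)(F)F`) carries a 2-chlorophenyl in the same place and in this assay compound 2 gives 2300 nM, the only real number so far. The step of an at least 13-fold lower number from compound 1 to compound 2 (1.11 log units; beyond the scatter) shows that the choice of aryl group on the sulfonyl sulfur matters a great deal here.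

Compound 3 (`CC(O)(C(=O)Nc1ccc(S(=O)(=O)c2ccc(Br)cc2)cc1)C(F)(F)F`) is the next change: 4-bromophenyl in place of 2-chlorophenyl on a sulfonyl sulfur. Among the measured compounds shown here, the only measured step runs from a 4-methoxyphenyl to a 2-chlorophenyl, so it bears on this change only loosely, as both leave the 2-chlorophenyl of compound 2 behind. Some loss in this assay is expected, but a smaller one than the measured step, as an expected step of a 2.6-fold higher number from compound 2 to compound 3 (0.42 log units; beyond the scatter). Compound 3 is therefore estimated to give about 6000 nM in this assay, with a range from 1500 nM to 30000 nM.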

Compound 3, half-maximal inhibitory concentration: > 30000 nM
Compound 3 gave a limit, no number; the forecaster's own chance of this, stated with the estimate: 25%; middle value at least 5.0-fold (0.69 log units) from the limit.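

Putting 4-bromophenyl in place of 2-chlorophenyl on the sulfonyl sulfur is a large change in this assay, with an at least 13-fold higher number from compound 2 to compound 3 (1.11 log units; beyond the scatter). Compound 3 gives > 30000 nM, which is a limit of the assay and not a number. This shows that a halogen on this aryl group is not enough on its own to give a measurable value, since the bromine-bearing compound 3 does not give one, and among these three compounds only the 2-chlorophenyl of compound 2 does; compound 1 and compound 3 cannot be ranked against each other, because neither gives a real number: the limit of > 30000 nM in this assay, at which 2 of the 3 values shown sit.

The two group names differ both in the halogen and in the number that marks its place, so these compounds cannot say which of the two matters, or whether both do. As far as these compounds go, it also remains open how the assay would respond to a plain phenyl with no halogen, or to an aryl group carrying an amine or a carboxylic acid on the sulfonyl sulfur.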